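Two Measured Compounds and One Expectation

This account rests on a few compounds, and the source may have more. Where it says the series, first, only, none or still open, it means among the compounds named here.

Compound 1, `O=C1OC(c2ccc(Cl)cc2)=C/C1=C\c1ccc(Cl)cc1Cl`: 72.6%
Compound 2, `O=C1/C(=C/c2ccc([N+](=O)[O-])cc2)C=C(c2ccc(Cl)cc2)N1Cc1ccccc1`: 19.8%

In a functional assay on the whole organism (strain Wistar) for inhibition, with Rattus norvegicus as the target, with stated times of 30 min and 3 h, at a dose of 20 mg/kg by the oral route (on this read-out higher numbers stand for more inhibition at the one dose given (going by the name of the read-out) and lower numbers for less inhibition), compound 1 gives 72.6% and compound 2 gives 19.8%. Compound 2 thus stands lowest of the two numbers; its nearest neighbour is compound 1, which lies well above it, beyond the scatter. Within the data shown here, no step between measured compounds that differ in one place is available, so the two values show only that compound 2 inhibits less than compound 1 at the dose given, and nothing more can be drawn from that pair.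

Compound 3, `COc1cc(/C=C2\C=C(c3ccc(Cl)cc3)N(Cc3ccccc3)C2=O)ccc1O`, differs from compound 2 in one place: 4-hydroxy-3-methoxyphenyl in place of 4-nitrophenyl on a double-bonded chain carbon bound to a double-bonded ring carbon. Among the measured compounds shown here, nothing among the measured compounds shows what this change does to the read-out. For the measured compounds named here, with no comparable step in hand, the step expected in this assay is of small size, its direction uncertain, and it may well stay within the scatter. Compound 3 is expected to give 30%, with a range from 5% to 60%. The step that this estimate means is a number 10.2 percentage points higher from compound 2 to compound 3 (beyond the scatter), an expected change of modest size upward.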

Compound 3, a percentage reported as inhibition, in the whole organism at one dose (the size of the read-out at that dose, not a potency): 42%
Compound 3: the middle estimate sits 12 percentage points below what was measured; measured number inside the range.
By their numbers in this assay, from the lowest: compound 2; then compound 3; then compound 1.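

Among these compounds, the exchange of 4-nitrophenyl for 4-hydroxy-3-methoxyphenyl on a double-bonded chain carbon bound to a double-bonded ring carbon gives the first one-place comparison in this assay, with a number 22.2 percentage points higher from compound 2 to compound 3 (beyond the scatter). The read-out at the one dose is therefore sensitive to the group at this position, since this single change in an otherwise shared structure moves it beyond the scatter, and the entering group carries a hydrogen-bond donor that the leaving group lacks. Nothing available bears on the reason for this step, so it stands as an observation without an explanation.

The change removes the nitro group and brings in the hydroxy and methoxy groups together, so the compounds shown leave open which part of it accounts for the step, and whether a phenyl carrying only a hydroxy group, only a methoxy group, or an amine such as dimethylamino would read the same way. From the compounds shown here alone, compound 1 differs from compound 2 and compound 3 in more than one place, so what separates it from them also remains open.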